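Methoxy in Place of Chloro: an Expected Solubility Outcome

The source may hold more compounds than are shown below. What is called first, only, known or untested is meant among the compounds shown, and "the series" means these compounds.

Compound 1 `OCCNc1nc(NCc2ccco2)c2ccccc2n1` gives >= 30000 nM in a physicochemical assay for solubility, at pH 2 (on this read-out higher numbers stand for higher solubility and lower numbers for lower solubility), a limit of the assay rather than a number.
Compound 2 `CC(C)Nc1nc(NCc2ccco2)c2c(Cl)cccc2n1` gives >= 30000 nM in this assay, again a limit of the assay.
Compound 3 `Cc1ccc2nc(NC(C)C)nc(NCc3ccco3)c2c1` gives >= 30000 nM in this assay, once more a limit of the assay.

Compound 2 therefore stands nowhere in particular among these three: for it only a limit is known, and the same holds for the other two, all three sitting at the limit of >= 30000 nM in this assay, at which 3 of the 3 values shown sit. Going by the values given here, no step between two measured compounds can be drawn from such values, so nothing is known about how any change on the shared core moves solubility here.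

Compound 4 `COc1cccc2nc(NC(C)C)nc(NCc3ccco3)c12` is the one still to be measured. It differs from compound 2 by methoxy in place of chloro on an aromatic carbon. Among the compounds with values here, with no measured step to lean on, the expectation rests only on the position of compound 2 at the limit. The step from compound 2 to compound 4 in this assay is expected to be none beyond the scatter, which is to say that compound 4 is expected to remain at or past the same limit, a step that the limit leaves unreadable from compound 2 to compound 4. The estimate for compound 4 in this assay is accordingly 50000 nM, with a range from 20000 nM to 150000 nM.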

Compound 4, solubility: >= 30000 nM
Compound 4: only a limit was reported; the forecaster's own chance of this, stated with the estimate: 85%; the middle value is on the limit's open side.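

No step from compound 2 to compound 4 can be read in this assay, because the values of both compounds are limits of the assay, as are those of compound 1 and compound 3: the limit of >= 30000 nM in this assay, at which 4 of the 4 values shown sit.

The compounds shown leave open how far each lies past that limit, and so whether methoxy in place of chloro on an aromatic carbon moves this read-out at all.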